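Methylsulfanyl in Place of Methyl on Two Cores

The source may hold more compounds than are shown below. What is called first, only, known or untested is meant among the compounds shown, and "the series" means these compounds.

Measured so far:
compound 1 `C[C@H]1O[C@@H](n2cnc3c(N)nc(N=[N+]=[N-])nc32)[C@H](O)[C@@H]1O`: 181000 nM
compound 2 `CS[C@H]1O[C@@H](n2cnc3c(N)nc(N=[N+]=[N-])nc32)[C@H](O)[C@@H]1O`: 236000 nM
compound 3 `CNc1ncnc2c1ncn2[C@@H]1O[C@H](C)[C@@H](O)[C@H]1O`: 266000 nM

In an ADME assay on L6 cells (Rattus norvegicus) for cytotoxicity (on this read-out higher numbers stand for weaker inhibition and lower numbers for stronger inhibition), compound 1 and compound 2 differ by one change, (methylsulfanyl in place of methyl on a saturated ring carbon), and the step is a 1.3-fold higher number from compound 1 to compound 2 (0.12 log units; within the scatter). Compound 3 carries a different core; how the core of compound 3 differs from that of compound 1 is not broken down here. Compound 4 `CNc1ncnc2c1ncn2[C@@H]1O[C@H](SC)[C@@H](O)[C@H]1O` is compound 3 with the same change, (methylsulfanyl in place of methyl on a saturated ring carbon), at a place described in the same words, so it is the same change. Compound 3 stands near compound 2 and compound 1 in this assay. Because a 1.3-fold higher number from compound 1 to compound 2 (0.12 log units; within the scatter) stayed within the scatter, the step from compound 3 to compound 4 is expected to be a 1.3-fold higher number from compound 3 to compound 4 (0.11 log units; within the scatter). Compound 4 is therefore estimated at 340000 nM, between 200000 nM and 560000 nM.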

Compound 4, half-maximal inhibitory concentration: 159000 nM
Estimate against measurement, compound 4: 2.1-fold (0.33 log units) above, outside the stated range (below it).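

In this assay, replacing methyl with methylsulfanyl on the second core gives a 1.7-fold lower number from compound 3 to compound 4 (0.22 log units; within the scatter). Set beside the step on the first core, this gives no sign that the outcome of the change depends on the core: the same change on two cores in this assay, a 1.3-fold higher number (0.12 log units; within the scatter) from compound 1 to compound 2 and a 1.7-fold lower number (0.22 log units; within the scatter) from compound 3 to compound 4, 2.2-fold (0.34 log units) apart, within the scatter of two such steps. Both steps are small enough to be lost in the scatter, so the pair does not show a reversal between the cores, and two cores alone do not show that the change would behave alike on others.

The compounds shown leave open whether a longer chain on the sulfur, or an amine or a carboxylic acid at the same place, would move the number beyond the scatter. On these data alone, whether the change stays this small on a third core also remains open.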